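Swapping the branched chain for a ring on the core nitrogen

The source may hold more compounds than are shown below. What is called first, only, known or untested is meant among the compounds shown, and "the series" means these compounds.

Compound 1 `CCC(CC)n1c(-c2ccc(OCc3c(-c4c(Cl)cccc4Cl)noc3C(C)C)cc2F)nc2ccc(C(=O)O)cc21` sits at the limit of an assay on HEK-293T cells for antagonist activity at vitamin D3 receptor (Homo sapiens), read by a luciferase reporter, with a stated time of 24 h; a higher number here means a weaker inhibitor, a lower number a stronger inhibitor: compound 1 gives > 10000 nM, which is a limit rather than a number, and this is the case described by the limit of > 10000 nM in this assay, at which 1 of the 3 values shown sits. Compound 2 `CCC(CC)n1c(-c2ccc(OCc3c(-c4c(Cl)cccc4Cl)noc3C(C)C)cc2)nc2ccc(C(=O)O)cc21`, which has hydrogen in place of fluoro on an aromatic carbon, gives 5690 nM in this assay, so the step of an at least 1.7-fold lower number from compound 1 to compound 2 (0.24 log units; that floor lies within the scatter) is only a floor. Compound 3 `CC(C)c1onc(-c2c(Cl)cccc2Cl)c1COc1ccc(-c2nc3cc(C(=O)O)ccc3n2C)cc1`, carrying a methyl on the core nitrogen, gives 4410 nM in this assay. The change to compound 4 `CC(C)c1onc(-c2c(Cl)cccc2Cl)c1COc1ccc(-c2nc3ccc(C(=O)O)cc3n2CC2CCCCC2)c(F)c1` is cyclohexylmethyl in place of pentan-3-yl on an aromatic nitrogen, with the fluoro kept. Among the compounds with values here, none of the measured steps touches that nitrogen substituent; compound 2 and compound 3 differ there, but their two values are what they are. The step that the limit leaves unreadable from compound 1 to compound 4 is therefore expected to be small in this assay, with no clear direction. Compound 4 is estimated at 12000 nM, within 4000 nM to 40000 nM, and may well again return only a limit.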

Compound 4, half-maximal inhibitory concentration: 840 nM
Compound 4: middle estimate off by 14-fold (1.15 log units), on the high side; measured number outside the range, below it.
By their numbers in this assay, from the lowest: compound 4; then compounds 3 and 2 (each within the scatter of the next). At a limit, above all of these: compound 1.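

Cyclohexylmethyl in place of pentan-3-yl on the aromatic nitrogen gives an at least 11-fold lower number from compound 1 to compound 4 (1.07 log units; beyond the scatter) in this assay. This is the first single change shown that lies beyond the scatter, so with the fluoro kept, the group on this nitrogen can clearly shift the number. Compound 1 stands at a limit rather than at a number, so the step is only a floor and its true size cannot be read: the limit of > 10000 nM in this assay, at which 1 of the 4 values shown sits.

The ring and the larger group enter together, so these compounds cannot separate the effect of the ring from that of the added size; an open heptyl chain or a benzyl group on this nitrogen would help to tell them apart. As far as these compounds go, whether cyclohexylmethyl gives a similar result with hydrogen in place of the fluoro also remains open.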